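Ethoxy for methyl on the nitro-bearing core

The source may hold more compounds than are shown below. What is called first, only, known or untested is meant among the compounds shown, and "the series" means these compounds.

The series rests on a shared core carrying an anilinomethyl arm, and all numbers come from an assay on isolated protein for inhibition of ribosomal protein S6 kinase alpha-2 (Homo sapiens), read by fluorescence, with a stated time of 20 min, tested at 10 uM; on this read-out lower numbers stand for less inhibition and higher numbers for more inhibition at the one concentration tested (going by the name of the read-out). Compound 1 `Cc1ccc(NCN2C(=O)c3ccccc3C2=O)cc1` gives 54% in this assay. Compound 2 `CCOc1ccc(NCN2C(=O)c3ccccc3C2=O)cc1` gives 100% in this assay, and compound 3 `Cc1ccc(NCN2C(=O)c3ccc([N+](=O)[O-])cc3C2=O)cc1` gives 35.7% in this assay. Compound 3 thus has the lowest number of the three: the step of a number 18.3 percentage points lower from compound 1 to compound 3 (beyond the scatter) separates it from compound 1, and compound 2 lies further away still, above the scatter in both cases.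

The unmeasured compound 4 `CCOc1ccc(NCN2C(=O)c3ccc([N+](=O)[O-])cc3C2=O)cc1` differs from compound 3 in one place: ethoxy in place of methyl on an aromatic carbon. The same change has been measured once before, between compound 1 and compound 2, where a number 46 percentage points higher from compound 1 to compound 2 (beyond the scatter) was seen. For the measured compounds named here, that single step is the only direct guide here, and it points upward by a large amount; compound 3 starts low enough that a rise of that size stays below the top of the scale. Going by the values given here, the one caveat is that the change has been seen only on the core without nitro, so its size on compound 3 is not guaranteed.

Compound 4 is therefore expected to show a number 44.3 percentage points higher from compound 3 to compound 4 (beyond the scatter) in this assay, giving an estimated 80% with a likely range from 55% to 100%.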

Compound 4, a percentage reported as inhibition, at one concentration (the size of the read-out at that concentration, not a potency): 87%
Estimate against measurement, compound 4: 7 percentage points below, within the range that was stated.
By their numbers in this assay, from the lowest: compound 3; then compound 1; then compound 4; then compound 2.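

In this assay, ethoxy in place of methyl, para to a large group, gives a number 51.3 percentage points higher from compound 3 to compound 4 (beyond the scatter), so the rise no longer rests on the core without nitro alone. Its size carries over from one core to the other, and the nitro group does not alter what this change does at this position: the same change on two cores in this assay, a number 46 percentage points higher (beyond the scatter) from compound 1 to compound 2 and a number 51.3 percentage points higher (beyond the scatter) from compound 3 to compound 4, 5.3 percentage points apart, within the scatter of two such steps The nitro group now also has a second reading, a number 13 percentage points lower from compound 2 to compound 4 (beyond the scatter), and the drop it brings matches on the methyl and ethoxy compounds, so in these four compounds the two changes behave independently of each other: the same change on two cores in this assay, a number 18.3 percentage points lower (beyond the scatter) from compound 1 to compound 3 and a number 13 percentage points lower (beyond the scatter) from compound 2 to compound 4, 5.3 percentage points apart, within the scatter of two such steps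

The compounds shown hold only methyl and ethoxy at this position, and each is read at a single concentration, so they give no potency and no trend with chain length. From the compounds shown here alone, whether methoxy, a longer chain such as propoxy or an amine would match ethoxy at this position, and whether the same independence would hold with a carboxylic acid in place of nitro on the core, remains open.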